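Compound 3: A Benzyl Group in Place of 3-Methylphenyl

The source may report more compounds than this note shows. Statements on the series, on what has been measured and on what is new or still open speak of the compounds shown alone.

Of the compounds shown here, two have so far been measured in an in vitro functional assay on cells for antagonist activity at transient receptor potential cation channel subfamily V member 1 (Homo sapiens), read by FLIPR and calcium flux; a lower number here means a stronger inhibitor, a higher number a weaker inhibitor. Compound 1 `O=C1CCc2cccc(Nc3ncc(-c4ccc(C(F)(F)F)cc4)o3)c2C1` gives 374 nM, while compound 2 `Cc1cccc(-c2cnc(Nc3cccc4c3CC(O)CC4)o2)c1` gives 157 nM, the lower of the two numbers, with compound 1 standing above it by a gap beyond the scatter. Compound 3 `OC1CCc2cccc(Nc3ncc(Cc4ccccc4)o3)c2C1` has the same atoms as compound 2, joined differently: benzyl in place of 3-methylphenyl on an aromatic carbon. For the measured compounds named here, no measured pair shows a change of this kind, so its effect in this assay is not known from the data. The author expects a weakening, a step of a 9.6-fold higher number from compound 2 to compound 3 (0.98 log units; beyond the scatter). Compound 3 is therefore estimated at 1500 nM, with a range from 300 nM to 8000 nM.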

Compound 3, half-maximal inhibitory concentration: 1820 nM
Compound 3: the middle estimate sits 1.2-fold (0.08 log units) below what was measured; the measured number falls inside the stated range.
By their numbers in this assay, from the lowest: compound 2; then compound 1; then compound 3.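

In this assay, placing benzyl in place of 3-methylphenyl next to the ring oxygen brings a 12-fold higher number from compound 2 to compound 3 (1.06 log units; beyond the scatter), so this position responds strongly to how the aromatic ring is attached. The two groups have the same heavy-atom, donor and acceptor counts, so these counts do not separate compound 2 from compound 3. Nothing measured here bears on the reason for this large step. The compounds shown leave open how a longer chain such as 2-phenylethyl, or a directly attached pyridine ring, would behave at this position.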